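Acetyl in place of ethoxycarbonyl on a cytotoxicity series

The compounds below may be only part of what the source reports. "The series", "measured", "known", "first", "only" and "open" are said of these compounds alone.

Compound 1: `Cc1ccc(NC(=O)CSc2nncnc2-c2cccc3ccccc23)c(Br)c1`, 166000 nM
Compound 2: `CCOC(=O)c1ccc(NC(=O)CSc2nncnc2-c2ccccc2Cl)c(Br)c1`, 69000 nM
Compound 3: `CCOC(=O)c1ccc(NC(=O)CSc2nncnc2-c2cccc3ccccc23)c(Cl)c1`, 150000 nM

Three compounds sharing one core were tested in an ADME assay on MT4 cells (Homo sapiens) for cytotoxicity, read by MTT assay; a lower number here means that less compound is tolerated, a higher number that more compound is tolerated. Compound 2 gives the lowest number of the three, 69000 nM; compound 3 gives the nearest number, 150000 nM, and compound 1 the furthest, 166000 nM, both gaps lying beyond the scatter. Compound 4 (`CC(=O)c1ccc(NC(=O)CSc2nncnc2-c2ccccc2Cl)c(Br)c1`) has not yet been measured. It differs from compound 2 in one place: methyl in place of ethoxy on a carbonyl carbon. Among the measured compounds shown here, no measured pair in this set shows what such a change does, so the step is expected to be small, with no direction beyond the scatter: a 1.1-fold higher number from compound 2 to compound 4 (0.04 log units; within the scatter). Compound 4 is therefore estimated at 75000 nM in this assay, within a range from 35000 nM to 160000 nM.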

Compound 4, half-maximal cytotoxic concentration: 34000 nM
Beside the measured number, compound 4's estimate is 2.2-fold (0.34 log units) above it, outside the stated range (below it).
By their numbers in this assay, from the lowest: compound 4; then compound 2; then compounds 3 and 1 (each within the scatter of the next).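

In this assay, among the compounds shown here, the change from ethoxycarbonyl to acetyl gives the first step in this set between compounds differing in one place, a 2.0-fold lower number from compound 2 to compound 4 (0.31 log units; beyond the scatter), and it shows that this carbonyl substituent affects the number. The step is modest but beyond the scatter, with less compound tolerated when methyl replaces ethoxy. Nothing available explains the shift. On these data alone, what a carboxylic acid or a longer chain at this carbonyl carbon would do remains open. So does whether the same change would act alike in compound 3.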